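The compounds below may be only part of what the source reports. "The series", "measured", "known", "first", "only" and "open" are said of these compounds alone.

Measured so far:
- Compound 1, `CNc1nc(N2CCC(N)CC2)c2sc(-c3ccc(C(F)(F)F)cc3)cc2n1`: 17 ug/mL
- Compound 2, `Nc1nc(NC2CCCNC2)c2sc(-c3ccc(C(F)(F)F)cc3)cc2n1`: 125 ug/mL
- Compound 3, `Nc1nc(NC2CCNC2)c2sc(-c3ccc(C(F)(F)F)cc3)cc2n1`: 155 ug/mL

In a physicochemical assay for solubility, in phosphate buffer, at pH 6.5 (a lower number here means a less soluble compound, a higher number a more soluble compound), compound 3 gives the highest of the three numbers. Its nearest neighbour is compound 2, and the step of a 1.2-fold higher number from compound 2 to compound 3 (0.09 log units; within the scatter) lies within the scatter, so the two are not ordered against each other. Compound 1 stands furthest away: compound 1 gives 17 ug/mL, while compound 3 gives 155 ug/mL, a gap beyond the scatter.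

Compound 4, `Nc1nc(N2CCC(N)CC2)c2sc(-c3ccc(C(F)(F)F)cc3)cc2n1`, is the next step: 4-aminopiperidin-1-yl in place of (pyrrolidin-3-yl)amino on an aromatic carbon. The group that leaves carries 2 hydrogen-bond donors and 2 acceptors on a five-membered ring; the group that enters carries 1 donor and 2 acceptors on a six-membered ring.

Among the compounds with values here, only one measured step bears on the change in ring, and that is the step from the six-membered to the five-membered ring of the amino-linked group, which was flat within the scatter. Within the data shown here, no measured step covers the change from an amino-linked ring to a ring attached through its own nitrogen. Compound 1 also carries 4-aminopiperidin-1-yl and sits low in this assay, so a drop is expected for compound 4: a 3.9-fold lower number from compound 3 to compound 4 (0.59 log units; beyond the scatter). The estimate for compound 4 is 40 ug/mL, with a range from 12 ug/mL to 120 ug/mL.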

Compound 4, solubility: 134 ug/mL
Estimate against measurement, compound 4: 3.4-fold (0.53 log units) below; the whole stated range lies below it.
By their numbers in this assay, from the lowest: compound 1; then compounds 2, 4 and 3 (each within the scatter of the next).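

In this assay, the exchange on the aromatic carbon next to the ring nitrogen gives no separation from either amino-linked ring: a 1.2-fold lower number from compound 3 to compound 4 (0.06 log units; within the scatter), and likewise a 1.1-fold higher number from compound 2 to compound 4 (0.03 log units; within the scatter), so among these three compounds neither the ring nor its mode of attachment orders the numbers. Within the data shown here, the only new step beyond the scatter lies at another place, hydrogen in place of methyl on a nitrogen on an aromatic ring, with a 7.9-fold higher number from compound 1 to compound 4 (0.90 log units; beyond the scatter), which shows that 4-aminopiperidin-1-yl does not by itself place a compound low in this assay. No measurement at hand accounts for either the flat steps at the ring position or the larger step at the methyl position.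

Going by these compounds, the methyl step rests on one pair, so it remains open whether it carries over to compounds with (pyrrolidin-3-yl)amino or (piperidin-3-yl)amino on the shared core. Also open, on these data alone, is how an ethyl group on that nitrogen, or a morpholin-4-yl or carboxylic acid-bearing ring in place of 4-aminopiperidin-1-yl, would read in this assay.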